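Swapping pyridin-4-yl for 4-hydroxyphenyl at the assay limit

The source may hold more compounds than are shown below. What is called first, only, known or untested is meant among the compounds shown, and "the series" means these compounds.

Measured so far in a functional assay on LNCaP cells (Homo sapiens) for antiproliferative activity, read by MTT assay, with a stated time of 24 h; a lower number here means a stronger inhibitor, a higher number a weaker inhibitor:
compound 1 `COc1ccc(-c2noc(-c3ccncc3)n2)cc1OC1CCCC1`: > 1000000 nM
compound 2 `COc1ccc(-c2noc(Cc3c[nH]c4ccccc34)n2)cc1OC1CCCC1`: > 1000000 nM

Compound 1 gives > 1000000 nM, which is a limit of the assay and not a number. Compound 2 gives > 1000000 nM, and this too is a limit. Neither compound therefore has a true potency on record, and the starting point is only the shared ceiling: the limit of > 1000000 nM in this assay, at which 2 of the 2 values shown sit.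

The next compound, compound 3 `COc1ccc(-c2noc(-c3ccc(O)cc3)n2)cc1OC1CCCC1`, keeps the core of compound 1 and changes one group. It carries 4-hydroxyphenyl in place of pyridin-4-yl on an aromatic carbon of a five-membered aromatic ring with 2 nitrogen and 1 oxygen: 4-hydroxyphenyl in place of pyridin-4-yl on an aromatic carbon.

Within the data shown here, no two measured compounds differ in just one place, so no measured step can guide this swap. Two different groups on the core have so far yielded no number in this assay, so only a modest move towards stronger inhibition is expected, and compound 3 may well stay at the limit. The expected change is an at least 2.0-fold lower number from compound 1 to compound 3 (0.30 log units; that floor lies within the scatter), towards a lower number. For compound 3 the estimated value is 500000 nM (expected range 100000 nM to 1000000 nM).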

Compound 3, half-maximal inhibitory concentration: 860 nM
Estimate against measurement, compound 3: 580-fold (2.76 log units) above; the measured number lies below the stated range.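

In this assay, this aromatic carbon of the five-membered aromatic ring with 2 nitrogen and 1 oxygen proves sensitive to the group it carries: 4-hydroxyphenyl in place of pyridin-4-yl gives an at least 1100-fold lower number from compound 1 to compound 3 (3.06 log units; beyond the scatter). Compound 1 gives > 1000000 nM, which is a limit and not a number, so the printed size of this step is only a minimum. Compound 3 is the only compound shown with a true potency, so this single change is what brings the series off the shared ceiling, which still holds most of the values: the limit of > 1000000 nM in this assay, at which 2 of the 3 values shown sit.

The swap makes two changes at once, removing the ring nitrogen of pyridin-4-yl and adding a hydroxy group, and the compounds shown cannot say which of them matters more or whether both are needed. Plain phenyl would separate the two changes, while 4-methoxyphenyl or 4-aminophenyl would test whether the hydroxy group itself is required, and the values shown give no hint of how any of these would behave.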